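Swapping an indolylmethyl group for a methylindolyl group

This account rests on a few compounds, and the source may have more. Where it says the series, first, only, none or still open, it means among the compounds named here.

In a functional assay on K562 cells (Homo sapiens) for inhibition, read by trypan blue exclusion, with a stated time of 72 h (a lower number here means a stronger inhibitor, a higher number a weaker inhibitor), compound 1 (`Cn1c(=O)c(S(=O)(=O)c2ccc(F)cc2F)cc2cnc(Nc3ccc4sccc4c3)nc21`) gives 500 nM and compound 2 (`Cn1c(=O)c(S(=O)(=O)c2ccc(F)cc2F)cc2cnc(NCc3ccc4[nH]ccc4c3)nc21`) gives 75000 nM as the higher of the two numbers. Compound 3 (`Cc1cc2cc(Nc3ncc4cc(S(=O)(=O)c5ccc(F)cc5F)c(=O)n(C)c4n3)ccc2[nH]1`) has the same atoms as compound 2, joined differently (2-methyl-1H-indol-5-yl in place of (1H-indol-5-yl)methyl on a nitrogen on an aromatic ring). Within the data shown here, the one measured step that bears on this (a 150-fold higher number from compound 1 to compound 2 (2.18 log units; beyond the scatter)) was large, and it brought in the same (1H-indol-5-yl)methyl that now leaves. A large step to a lower number is therefore expected (a 94-fold lower number from compound 2 to compound 3 (1.97 log units; beyond the scatter)). Compound 3 is thus expected to read 800 nM with 150 nM to 5000 nM as its estimated range.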

Compound 3, half-maximal inhibitory concentration: 750 nM
For compound 3 the middle estimate is 1.1-fold (0.03 log units) above the measured one, and the stated range covers the measured number.
By their numbers in this assay, from the lowest: compounds 1 and 3 (each within the scatter of the next); then compound 2.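

In this assay, attaching the indole directly to the nitrogen on the aromatic ring, as 2-methyl-1H-indol-5-yl, goes with a 100-fold lower number from compound 2 to compound 3 (2.00 log units; beyond the scatter), although the entering and leaving groups have the same heavy atoms. Against the 1-benzothiophen-5-yl of compound 1, the change gives a 1.5-fold higher number from compound 1 to compound 3 (0.18 log units; within the scatter), so these two groups cannot be told apart on this nitrogen. Nothing available explains the large step. The compounds shown leave open how much of that step belongs to the methylene link and how much to the 2-methyl group, which a plain 1H-indol-5-yl would separate. Going by these compounds, how a carboxylic acid on this group would read also stays open.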